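Ether chain trimming on the shared core: methyl removed

The compounds below may be only part of what the source reports. "The series", "measured", "known", "first", "only" and "open" are said of these compounds alone.

Measured so far:
compound 1 `CCCC(C)Oc1cccc2ccc(N)nc12` — 105 nM
compound 2 `Nc1ccc2cccc(OCC3CC4CCC3C4)c2n1` — 137 nM
compound 3 `CC(CC(C)(C)C)Oc1cccc2ccc(N(C)C)nc12` — > 2000 nM

In an assay on cells with melanin-concentrating hormone receptor 1 (Homo sapiens) as the target, read by radioligand binding (on this read-out lower numbers stand for stronger inhibition and higher numbers for weaker inhibition), compound 1 gives 105 nM, the lowest of the two numbers reported. Compound 2 gives 137 nM, a gap from compound 1 that lies within the scatter, so the two are read as equivalent. For compound 3 the assay reports only a limit, > 2000 nM (the limit of > 2000 nM in this assay, at which 1 of the 3 values shown sits), and no number is available for it.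

Compound 4 `CCCCOc1cccc2ccc(N)nc12` has not yet been measured in this assay. It differs from compound 1 by hydrogen in place of methyl on a saturated chain carbon bound to an oxygen on an aromatic ring and a saturated chain carbon; cut one bond further out, the same difference reads 1-methylbutyl to butyl. For the measured compounds named here, no pair of measured compounds shows this step, so its size must be guessed from compound 1 alone, whose value 105 nM is the anchor.

The expectation is a small step, if any, from compound 1 to compound 4, in the direction of a slightly higher number, estimated as a 1.4-fold higher number from compound 1 to compound 4 (0.15 log units; within the scatter). Compound 4 is therefore expected at 150 nM, with a range from 60 nM to 400 nM.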

Compound 4, half-maximal inhibitory concentration: 789 nM
Beside the measured number, compound 4's estimate is 5.3-fold (0.72 log units) below it, and the stated range ends below it.
By their numbers in this assay, from the lowest: compounds 1 and 2 (each within the scatter of the next); then compound 4. At a limit, above all of these: compound 3.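

In this assay, for the compounds shown here, the change from 1-methylbutyl to butyl gives a 7.5-fold higher number from compound 1 to compound 4 (0.88 log units; beyond the scatter) and is the only step that can be read. On the shared core, the methyl on the saturated chain carbon bound to an oxygen on an aromatic ring therefore carries real weight, and the unbranched butyl ether keeps a measurable but clearly weaker number. No measurement shown gives a cause for this step.

As far as these compounds go, whether the methyl matters for its own sake or any branch at this place would serve remains open, as this single pair cannot separate the two. An ethyl group in place of the methyl, or a longer chain on the same carbon, would show how far the effect extends.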